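The source may report more compounds than this note shows. Statements on the series, on what has been measured and on what is new or still open speak of the compounds shown alone.

Of the compounds shown here, three have so far been tested in an ADME assay on RAW264.7 cells (Mus musculus) for cytotoxicity, read by MTT assay, with a stated time of 24 h, in the absence of a further agent; on this read-out lower numbers stand for stronger inhibition and higher numbers for weaker inhibition. Compound 1 `O=C1OC(Cc2nc(-c3ccccc3)no2)c2ccccc21` carries a core of its own; in this assay compound 1 returns only a limit, > 40000 nM. Compound 2 `COCCOc1ccc(C(O)C2OC(=O)c3c(OC)cc(OC)cc32)cc1` and compound 3 `COc1cc(OC)c2c(c1)C(C(O)c1ccc(OCCOc3ccccc3)cc1)OC2=O` share a second core. In this assay compound 2 gives a limit as well, > 40000 nM. In this assay compound 3 likewise gives a limit, > 40000 nM. Compound 2 thus stands at a limit rather than at a number, and the two further values shown are limits too. Within the data shown here, the single one-place step among the measured compounds, a step that the two limits leave unreadable from compound 2 to compound 3, phenyl in place of methyl on an oxygen on a saturated carbon, has no readable size because of the limit of > 40000 nM in this assay, at which 3 of the 3 values shown sit.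

Compound 4 `COc1cc(OC)c2c(c1)C(C(O)c1ccc(OCc3ccc(C#N)cc3)cc1)OC2=O` awaits measurement in this assay. It differs from compound 2 by 4-cyanophenyl in place of methoxymethyl on a saturated chain carbon bound to an oxygen on an aromatic ring. Among the measured compounds shown here, no measured step bears on this change with a readable size: the only step available, the one from compound 2 to compound 3 in this assay, lies between two limits. The step that the limit leaves unreadable from compound 2 to compound 4 is therefore expected to stay within the scatter. Compound 4 is expected to come out near 60000 nM, within a range from 20000 nM to 200000 nM, most probably again reported only as a limit.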

Compound 4, half-maximal inhibitory concentration: > 40000 nM
Compound 4 ended at the assay's limit (the forecaster's own chance of this, stated with the estimate: 80%); the middle value lies beyond the limit too.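

No size can be read for the steps from compound 2 to compound 4 or from compound 3 to compound 4, because both ends of each step lie at a limit: the limit of > 40000 nM in this assay, at which 4 of the 4 values shown sit.

The compounds shown leave open whether any change on the shared core would produce a readable value in this assay.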